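Swapping the indole of compound 3 for a vinylphenyl group

The source may report more compounds than this note shows. Statements on the series, on what has been measured and on what is new or still open speak of the compounds shown alone.

Measured compounds:
compound 1, `COc1ccc(-c2cc3nccc(-c4cc(OC)c(OC)c(OC)c4)n3n2)cc1N`: 88 nM
compound 2, `COc1ccc(-c2cc3nccc(-c4cc(OC)c(OC)c(OC)c4)n3n2)cc1F`: 3950 nM
compound 3, `COc1cc(-c2ccnc3cc(-c4cn(C)c5ccccc45)nn23)cc(OC)c1OC`: 185 nM

In a functional assay on B16-F0 cells (Mus musculus) for inhibition, read by CCK-8 assay, with a stated time of 48 h (a lower number here means a stronger inhibitor, a higher number a weaker inhibitor), compound 3 stands second of the three, with compound 1 nearest (a 2.1-fold higher number from compound 1 to compound 3 (0.32 log units; beyond the scatter)) and compound 2 furthest (a 21-fold lower number from compound 2 to compound 3 (1.33 log units; beyond the scatter)). Compound 4, `C=Cc1ccc(-c2cc3nccc(-c4cc(OC)c(OC)c(OC)c4)n3n2)cc1`, differs from compound 3 at the same aromatic carbon: 4-vinylphenyl in place of 1-methyl-1H-indol-3-yl on an aromatic carbon. Within the data shown here, the steps that bear on this position, a 2.1-fold higher number from compound 1 to compound 3 (0.32 log units; beyond the scatter) and a 21-fold lower number from compound 2 to compound 3 (1.33 log units; beyond the scatter), show that the group here moves the number widely; the step of a 45-fold higher number from compound 1 to compound 2 (1.65 log units; beyond the scatter) shows that even a small change on a phenyl at this place can be large. Compound 4 is therefore expected to give a weaker number than compound 3, estimated at 600 nM (range 120 nM to 3000 nM), a step of a 3.2-fold higher number from compound 3 to compound 4 (0.51 log units; beyond the scatter).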

Compound 4, half-maximal inhibitory concentration: 788 nM
Compound 4: middle estimate off by 1.3-fold (0.12 log units), on the low side; the measured number falls inside the stated range.
By their numbers in this assay, from the lowest: compound 1; then compound 3; then compound 4; then compound 2.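

In this assay there is a 5.0-fold lower number from compound 2 to compound 4 (0.70 log units; beyond the scatter) and yet a 9.0-fold higher number from compound 1 to compound 4 (0.95 log units; beyond the scatter), so a phenyl bearing only a vinyl group, with no hydrogen-bond donors or acceptors, still falls short of 3-amino-4-methoxyphenyl at this position. With a 4.3-fold higher number from compound 3 to compound 4 (0.63 log units; beyond the scatter) as well, the phenyl groups do not all lie on one side of 1-methyl-1H-indol-3-yl: compound 1 gives a lower number, while compound 2 and compound 4 give higher ones. Nothing available explains this order. Still open, as far as these compounds go, is whether an ethyl group in place of the vinyl, or an amine on the same phenyl, would recover the number of compound 1.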